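A one-carbon chain extension in a phenylalkylamide series

This account rests on a few compounds, and the source may have more. Where it says the series, first, only, none or still open, it means among the compounds named here.

Compound 1 `COc1ccc(CCCNC(C)=O)cc1` was tested in an assay for binding affinity to melatonin receptor (Gallus gallus) (a lower number here means a stronger inhibitor, a higher number a weaker inhibitor), and gave 14000 nM. That is the higher of the two numbers recorded, yet compound 2 `CCCCC(=O)NCCCCc1ccccc1OC` gave 9190 nM, and the two values lie within the scatter of each other, so neither can be called the stronger. Compound 3 `COc1ccc(CCCCNC(C)=O)cc1` is still to be measured. It differs from compound 1 by acetamidomethyl in place of acetamido on a saturated chain carbon, three bonds along the chain from an aromatic carbon. Among the measured compounds shown here, no step of this kind has been measured, and compound 2 offers no direct comparison, so no change beyond the scatter is expected; the step is estimated as a 1.2-fold lower number from compound 1 to compound 3 (0.07 log units; within the scatter). Compound 3 is therefore expected to give about 12000 nM, with a range from 4000 nM to 40000 nM.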

Compound 3, inhibition constant: 7300 nM
The estimate for compound 3 lay 1.6-fold (0.22 log units) above the measured number, within the range that was stated.
By their numbers in this assay, from the lowest: compounds 3, 2 and 1 (each within the scatter of the next).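

In this assay, acetamidomethyl in place of acetamido on a saturated chain carbon, three bonds along the chain from an aromatic carbon, amounts to a 1.9-fold lower number from compound 1 to compound 3 (0.28 log units; within the scatter). Among the compounds shown here, this is the first step read at this position, and at this size it does not separate the two compounds. No supporting evidence bears on this result. On these data alone, whether a longer chain at this place would give a step beyond the scatter remains open. So does what an amine or a carboxylic acid in place of the amide would do to the number.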